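The compounds below may be only part of what the source reports. "The series", "measured", "known", "first", "only" and "open" are said of these compounds alone.

Measured in a functional assay on MCF7 cells (Homo sapiens) for inhibition, read by MTT assay, with a stated time of 72 h; a lower number here means a stronger inhibitor, a higher number a weaker inhibitor:
- Compound 1 `CCCCc1ccc(NC(=O)C2CCN(C/C=C/c3ccccc3)CC2)cc1`: 5870 nM
- Compound 2 `COc1ccc(NC(=O)C2CCN(C/C=C/c3ccccc3)CC2)cc1`: > 100000 nM, a limit of the assay
- Compound 3 `COc1cccc(NC(=O)C2CCN(C/C=C/c3ccccc3)CC2)c1`: 42700 nM

Only two of these results are actual numbers, since compound 2 reached a limit. Compound 3, at 42700 nM, holds the higher of the two, and compound 1 gives the lower at 5870 nM.

Compound 4 `O=C(Nc1cccc(Cl)c1)C1CCN(C/C=C/c2ccccc2)CC1` differs from compound 3 by chloro in place of methoxy on an aromatic carbon, meta to a large group (chloro in place of methoxy on an aromatic carbon). Going by the values given here, no measured step tests chloro directly, so the evidence is indirect. Methoxy in place of butyl gave an at least 17-fold higher number from compound 1 to compound 2 (1.23 log units; beyond the scatter), a large step. 3-Methoxyphenyl in place of 4-methoxyphenyl gave an at least 2.3-fold lower number from compound 2 to compound 3 (0.36 log units; beyond the scatter), an at least modest one. Both show that the numbers in this assay respond to changes on this aromatic ring. Both methoxy compounds also sit higher than compound 1, which has no methoxy, so a modest fall is expected on losing the methoxy. The expected change is a 2.1-fold lower number from compound 3 to compound 4 (0.33 log units; beyond the scatter). For compound 4 the estimated value is 20000 nM, with an expected range from 6000 nM to 60000 nM.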

Compound 4, half-maximal inhibitory concentration: 16100 nM
Beside the measured number, compound 4's estimate is 1.2-fold (0.09 log units) above it; the range from low to high includes it.
By their numbers in this assay, from the lowest: compound 1; then compound 4; then compound 3. At a limit, above all of these: compound 2.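

In this assay, the place on an aromatic carbon meta to a large group proved open to a group other than methoxy: chloro in place of methoxy gave a 2.7-fold lower number from compound 3 to compound 4 (0.42 log units; beyond the scatter). The earlier steps shown here had changed the group at another place or moved the methoxy, whereas this one exchanges the group at this place itself and shows that the number responds to that exchange. With 3-chlorophenyl in place of 4-methoxyphenyl on the amide-type nitrogen, the result is an at least 6.2-fold lower number from compound 2 to compound 4 (0.79 log units; beyond the scatter), and the value of compound 2 in that step is a limit: the limit of > 100000 nM in this assay, at which 1 of the 4 values shown sits.

The compounds shown leave open how this place would respond to an amine, a carboxylic acid or a longer chain. They also do not tell why the number fell on going from methoxy to chloro.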